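The compounds below may be only part of what the source reports. "The series", "measured", "known", "first", "only" and "open" are said of these compounds alone.

Compound 1 `COc1ccc(-c2nc3cc(-c4nc5cc(N6CCN(C)CC6)ccc5[nH]4)ccc3[nH]2)cc1`: 570 nM
Compound 2 `COc1ccc(-c2nc3cc(-c4nc5cc(CCCN(C)C)ccc5[nH]4)ccc3[nH]2)cc1`: 7100 nM

Compound 2 gives the higher of the two numbers in a functional assay on RPMI 8402 cells (Homo sapiens) for cytotoxicity; on this read-out higher numbers stand for weaker inhibition and lower numbers for stronger inhibition; compound 1 sits well away from it, as the step of a 12-fold higher number from compound 1 to compound 2 (1.10 log units; beyond the scatter) shows. Compound 3 `COc1ccc(-c2nc3cc(-c4nc5cc(CN(C)C)ccc5[nH]4)ccc3[nH]2)cc1` differs from compound 2 by dimethylamino in place of 2-(dimethylamino)ethyl on a saturated chain carbon bound to an aromatic carbon. Within the data shown here, no measured step shortens this chain; the only step in hand swaps a ring for a chain and is large, so this tail region clearly matters, but its direction here is unknown. Compound 3 is therefore expected to stay near compound 2, with a wide range, a step of a 1.4-fold lower number from compound 2 to compound 3 (0.15 log units; within the scatter); its estimate is 5000 nM, between 1500 nM and 15000 nM.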

Compound 3, half-maximal inhibitory concentration: 6300 nM
Estimate against measurement, compound 3: 1.3-fold (0.10 log units) below, and the stated range covers the measured number.
By their numbers in this assay, from the lowest: compound 1; then compounds 3 and 2 (each within the scatter of the next).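

In this assay, going from 3-(dimethylamino)propyl to (dimethylamino)methyl gives a 1.1-fold lower number from compound 2 to compound 3 (0.05 log units; within the scatter) and so leaves no readable effect of chain length between these two tails. The shorter tail also stays far from the 4-methylpiperazin-1-yl group, with an 11-fold higher number from compound 1 to compound 3 (1.04 log units; beyond the scatter) showing that the large gap is not peculiar to the longer chain. Nothing available explains either result.

As far as these compounds go, it remains open whether the ring itself matters, since neither a piperidine nor a morpholine has been compared in this place. From the compounds shown here alone, the effect of a 4-methylpiperazin-1-yl group held on a saturated chain carbon also remains open.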